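The source may hold more compounds than are shown below. What is called first, only, known or untested is meant among the compounds shown, and "the series" means these compounds.

Series notes. Compound 1 `O=C(O)CCc1c(-c2cccnc2)ccc2c1CCC(NS(=O)(=O)c1ccc(Cl)cc1)C2`, compound 2 `O=C(O)CCc1cc(Cc2cccnc2)cc2c1CCC(NS(=O)(=O)c1ccc(Cl)cc1)C2` and compound 3 `Cc1c(Cc2cccnc2)cc2c(c1CCC(=O)O)CCC(NS(=O)(=O)c1ccc(Cl)cc1)C2` share one core and one sulfonamide; they differ at the aromatic ring that carries the 2-carboxyethyl group. In an assay on blood with Thromboxane-A synthase (Homo sapiens) as the target (on this read-out higher numbers stand for weaker inhibition and lower numbers for stronger inhibition), compound 1 gives > 10000 nM, which is a limit of the assay and not a number. In this assay compound 2 gives 1100 nM and compound 3 gives 850 nM; the step of a 1.3-fold lower number from compound 2 to compound 3 (0.11 log units; within the scatter) is within the scatter, so the two stand level. Compound 3 thus holds the lowest of the two numbers, with compound 2 alongside it and compound 1 at the limit.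

Compound 4 `O=C(O)CCc1c2c(cc(Cc3cccnc3)c1-c1ccccc1)CC(NS(=O)(=O)c1ccc(Cl)cc1)CC2` is the next member. The change from compound 3 is phenyl in place of methyl on an aromatic carbon. The only measured step at this carbon is a 1.3-fold lower number from compound 2 to compound 3 (0.11 log units; within the scatter), a small one; no step with a phenyl at this position is shown. On that basis compound 4 is expected to stay near compound 3, with the estimated step of a 1.2-fold lower number from compound 3 to compound 4 (0.08 log units; within the scatter) carrying wide uncertainty. For compound 4 in this assay the estimate is 700 nM, between 150 nM and 3500 nM.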

Compound 4, half-maximal inhibitory concentration: > 10000 nM
Compound 4 gave a limit, no number; the forecaster's own chance of this, stated with the estimate: 10%; at least 14-fold (1.15 log units) between middle value and limit.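

In this assay, the earlier step at this aromatic carbon, a 1.3-fold lower number from compound 2 to compound 3 (0.11 log units; within the scatter), gave no sign that the position could matter, but a phenyl here gives an at least 11-fold higher number from compound 3 to compound 4 (1.07 log units; beyond the scatter). Against hydrogen, the same phenyl gives an at least 9.0-fold higher number from compound 2 to compound 4 (0.95 log units; beyond the scatter). Both of these steps rest on a limit of the assay and not on a number, so among the three groups shown at this carbon, ortho to a (pyridin-3-yl)methyl group and ortho to a 2-carboxyethyl group, hydrogen and methyl stand level while phenyl alone carries a step beyond the scatter.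

Open, as far as these compounds go, is how an ethyl, a methoxy or a cyclohexyl at this carbon would read, and so whether the rise follows the aromatic ring or the added heavy atoms. A phenyl carrying an amine or a carboxylic acid is open as well.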